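The source may report more compounds than this note shows. Statements on the series, on what has been measured and on what is new or still open speak of the compounds shown alone.

Among the compounds with values here, in a functional assay on DU-145 cells (Homo sapiens) for inhibition, read by trypan blue exclusion, with a stated time of 96 h (on this read-out lower numbers stand for stronger inhibition of growth and higher numbers for weaker inhibition of growth), compound 1 `O=C(/C(=C\c1ccc([N+](=O)[O-])c(O)c1)SCc1ccc(Br)cc1)c1ccc([N+](=O)[O-])cc1` gives 1000 nM and compound 2 `O=C(/C(=C\c1ccc([N+](=O)[O-])c(O)c1)SCc1ccc(Br)cc1)c1ccc(C(F)(F)F)cc1` gives 1000 nM, together the lowest numbers so far, while compound 3 `O=C(/C(=C\c1ccc(Cl)c([N+](=O)[O-])c1)S(=O)(=O)c1ccc(Br)cc1)c1ccc(Br)cc1` gives 10000 nM. Compound 4 `O=C(O)c1ccc(C(=O)/C(=C\c2ccc([N+](=O)[O-])c(O)c2)SCc2ccc(Br)cc2)cc1` departs from compound 2 by a single change, carboxy in place of trifluoromethyl on an aromatic carbon. Within the data shown here, only one measured step bears on this, a swap on that same aromatic carbon: no change at the digits printed from compound 1 to compound 2 (within the scatter). That one step is thin support, since carboxy is neither of the two groups it compares, so only a modest move towards weaker inhibition in this assay is expected. The expected change is a 2.0-fold higher number from compound 2 to compound 4 (0.30 log units; within the scatter). For compound 4 the estimated value is 2000 nM, within an expected range of 700 nM to 8000 nM.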

Compound 4, concentration for 50% growth inhibition: 10000 nM
Compound 4: the middle estimate sits 5.0-fold (0.70 log units) below what was measured; the whole stated range lies below it.
By their numbers in this assay, from the lowest: compounds 1 and 2 (each within the scatter of the next); then compounds 3 and 4 (each within the scatter of the next).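

In this assay, carboxy on this aromatic carbon brings a 10-fold higher number from compound 2 to compound 4 (1.00 log units; beyond the scatter) and a 10-fold higher number from compound 1 to compound 4 (1.00 log units; beyond the scatter). The earlier swap showed only that trifluoromethyl and nitro cannot be told apart here, whereas this result shows that growth inhibition at this position does depend on the group it carries. Nothing available explains the weaker inhibition with carboxy. The compounds shown leave open how a methyl ester or an amine on this carbon would read, and so whether the free carboxylic acid itself matters.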